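The source may hold more compounds than are shown below. What is called first, only, known or untested is meant among the compounds shown, and "the series" means these compounds.

In a functional assay on HT-29 cells (Homo sapiens) for inhibition, read by luminescence and CellTiter-Glo, with a stated time of 24 h (on this read-out higher numbers stand for an effect only at larger amounts of compound and lower numbers for an effect already at smaller amounts), three compounds sharing one core have been measured, and they differ in the group on an aromatic nitrogen. Compound 1 `CC(C)n1nc(C(=O)N[C@H]2COc3ccccc3N(C)C2=S)nc1Cc1ccccc1` gives 360 nM on this scale. Compound 2 `CC(C)CCn1nc(C(=O)N[C@H]2COc3ccccc3N(C)C2=S)nc1Cc1ccccc1` gives 3640 nM and compound 3 `CN1C(=S)[C@@H](NC(=O)c2nc(Cc3ccccc3)n(CCCC(F)(F)F)n2)COc2ccccc21` gives 2380 nM on the same scale. Compound 2 therefore stands with compound 3 at the upper end of the numbers, well away from compound 1.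

The step followed here leads from compound 2 to the unmeasured compound 4 `CN1C(=S)[C@@H](NC(=O)c2nc(Cc3ccccc3)n(CCCCC#N)n2)COc2ccccc21`. The change is this: 2-cyanoethyl in place of isopropyl on a saturated chain carbon, two bonds along the chain from an aromatic nitrogen (2-cyanoethyl in place of isopropyl on a saturated chain carbon, two bonds along the chain from an aromatic nitrogen, or isopentyl to 4-cyanobutyl when cut one bond further out).

Among the compounds with values here, the closest precedent is a 1.5-fold lower number from compound 2 to compound 3 (0.18 log units; within the scatter) which also alters the outer part of the chain and stays within the scatter. The larger steps, a 10-fold higher number from compound 1 to compound 2 (1.00 log units; beyond the scatter) and a 6.6-fold higher number from compound 1 to compound 3 (0.82 log units; beyond the scatter) both start from the isopropyl group of compound 1, a group that neither compound 2 nor compound 4 carries on the nitrogen. Within the data shown here, no measured compound holds a nitrile, so that group remains untested.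

No step beyond the scatter is therefore expected in this assay for this change. The estimated step is a 1.5-fold lower number from compound 2 to compound 4 (0.16 log units; within the scatter) and it is expected to stay small. For compound 4 the estimated value is 2500 nM with an expected range from 800 nM to 8000 nM on this scale.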

Compound 4, half-maximal effective concentration: 2680 nM
Compound 4: the middle estimate sits 1.1-fold (0.03 log units) below what was measured; the range from low to high includes it.
By their numbers in this assay, from the lowest: compound 1; then compounds 3, 4 and 2 (each within the scatter of the next).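

With a nitrile at the chain end, the result in this assay shows that this outer position accepts a third kind of end group without a step beyond the scatter: the change gives a 1.4-fold lower number from compound 2 to compound 4 (0.13 log units; within the scatter) and, against the fluorinated chain, a 1.1-fold higher number from compound 3 to compound 4 (0.05 log units; within the scatter). Compounds 2, 3 and 4 therefore form one group, in which the branched isopentyl, the 4,4,4-trifluorobutyl and the 4-cyanobutyl chains cannot be told apart, and none of the compounds shown goes against this. Only the group on the aromatic nitrogen of compound 1 still stands apart, as a 7.4-fold higher number from compound 1 to compound 4 (0.87 log units; beyond the scatter) confirms for the new chain, but no measurement among these data accounts for either the gap or the level values.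

The compounds shown leave open whether an amine or a carboxylic acid at the end of the chain would also stay level with compounds 2, 3 and 4. They also leave open whether an ethyl or cyclopropyl group on the aromatic nitrogen would match compound 1, or where between isopropyl and the longer chains the gap opens.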